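Oxolanyl replaces isopropyl on a pyrazole nitrogen

The compounds below may be only part of what the source reports. "The series", "measured", "known", "first", "only" and "open" are said of these compounds alone.

Two compounds share a core built from a methyl-substituted benzamide joined to a trifluoromethyl-bearing aniline and an indazole. Compound 1 `Cc1ccc(C(=O)Nc2cc(CN3CCN(C)CC3)cc(C(F)(F)F)c2)cc1-c1ccc2cn[nH]c2c1` carries a piperazinylmethyl group on the aniline ring, and in an assay on isolated protein for inhibition of Discoidin domain-containing receptor 2 (Homo sapiens), read by ELISA, with a stated time of 60 min (a lower number here means a stronger inhibitor, a higher number a weaker inhibitor), compound 1 gives 4.7 nM. Compound 2 `Cc1ccc(C(=O)Nc2cccc(C(F)(F)F)c2)cc1-c1ccc2c(-c3cnn(C(C)C)c3)n[nH]c2c1` lacks that group but carries an isopropyl-substituted pyrazole on the indazole; in this assay compound 2 gives 7.7 nM. The two numbers sit within the usual scatter of each other, so the measurements tell them apart no further.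

Compound 3 `Cc1ccc(C(=O)Nc2cccc(C(F)(F)F)c2)cc1-c1ccc2c(-c3cnn(C4CCOC4)c3)n[nH]c2c1` keeps the whole skeleton of compound 2 and changes only the substituent on the pyrazole nitrogen: oxolan-3-yl in place of isopropyl on an aromatic nitrogen. Among the compounds with values here, no measured pair here shows what such a swap does, so the expectation rests on the small size of the change and on compound 2 giving 7.7 nM as the starting point. The step from compound 2 to compound 3 is expected to be a 1.0-fold higher number from compound 2 to compound 3 (0.02 log units; within the scatter), small and not clearly beyond the scatter. In this assay compound 3 is therefore estimated at 8 nM, with a likely range from 3 nM to 25 nM.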

Compound 3, half-maximal inhibitory concentration: 6.2 nM
For compound 3 the middle estimate is 1.3-fold (0.11 log units) above the measured one; measured number inside the range.
By their numbers in this assay, from the lowest: compounds 1, 3 and 2 (each within the scatter of the next).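

In this assay, within the data shown here, putting oxolan-3-yl in place of isopropyl on an aromatic nitrogen gives a 1.2-fold lower number from compound 2 to compound 3 (0.09 log units; within the scatter), and this is the first measured pair here that differs in one place only. The result shows that this position accepts a group of 5 heavy atoms with a non-aromatic ring and a hydrogen-bond acceptor in place of one of 3 carbon atoms, with no difference that this assay can separate from the scatter. Nothing measured here explains why the two numbers stay so close.

What the compounds shown leave open is how far this tolerance reaches, since only two groups have been compared at this nitrogen, and neither of them carries a charge: an amine such as a piperidine ring, or a carboxylic acid at the end of a longer chain, could behave quite differently. They also leave open whether the piperazinylmethyl group that compound 1 carries would alter the number if it were added to compound 3.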